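This account rests on a few compounds, and the source may have more. Where it says the series, first, only, none or still open, it means among the compounds named here.

Compound 1 `O=[N+]([O-])c1ccc(C(c2c[nH]c3ccc([N+](=O)[O-])cc23)c2c[nH]c3ccc([N+](=O)[O-])cc23)cc1` carries a 4-nitrophenyl on a saturated chain carbon bound to two aromatic carbons. In a functional assay on HeLa cells (Homo sapiens) for inhibition, read by MTT assay, with a stated time of 48 h (on this read-out lower numbers stand for stronger inhibition and higher numbers for weaker inhibition), compound 1 gives only a limit of the assay, > 100000 nM. Compound 2 `CCCCCCCC(c1c[nH]c2ccc([N+](=O)[O-])cc12)c1c[nH]c2ccc([N+](=O)[O-])cc12` differs from compound 1 by heptyl in place of 4-nitrophenyl on a saturated chain carbon bound to two aromatic carbons. In this assay compound 2 gives 35000 nM. That change made an at least 2.8-fold lower number from compound 1 to compound 2 (0.45 log units; beyond the scatter), and the step is known only as a bound because compound 1 sits at the limit of > 100000 nM in this assay, at which 2 of the 3 values shown sit.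

Compound 3 `N#Cc1ccc2[nH]cc(C(c3ccc([N+](=O)[O-])cc3)c3c[nH]c4ccc(C#N)cc34)c2c1` is built on a different core; how the cores of compound 1 and compound 3 differ is not broken down here. In this assay compound 3 gives only a limit of the assay, > 100000 nM. Compound 4 `CCCCCCCC(c1c[nH]c2ccc(C#N)cc12)c1c[nH]c2ccc(C#N)cc12` arises from compound 3 by the same change, (heptyl in place of 4-nitrophenyl on a saturated chain carbon bound to two aromatic carbons), at the same place.

Among the compounds with values here, since compound 3 starts from a limit, the expected step is an at least 2.5-fold lower number from compound 3 to compound 4 (0.39 log units; beyond the scatter), resting on the one measured pair, an at least 2.8-fold lower number from compound 1 to compound 2 (0.45 log units; beyond the scatter). Compound 4 is therefore expected to give about 40000 nM in this assay, estimated to lie between 15000 nM and 150000 nM.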

Compound 4, half-maximal inhibitory concentration: 7000 nM
Compound 4: the middle estimate sits 5.7-fold (0.76 log units) above what was measured; the whole stated range lies above it.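

Heptyl in place of 4-nitrophenyl on a saturated chain carbon bound to two aromatic carbons lowers the number on a second core in this assay, with an at least 14-fold lower number from compound 3 to compound 4 (1.15 log units; beyond the scatter), so the direction of the change carries over from the core of compound 1 to the core of compound 3. This shows the same direction on these two cores only, and it does not show that the size of the step carries over: the same change on two cores in this assay, an at least 2.8-fold lower number (0.45 log units; beyond the scatter) from compound 1 to compound 2 and an at least 14-fold lower number (1.15 log units; beyond the scatter) from compound 3 to compound 4; the limit leaves it open whether they differ. Neither step has a measured number at its starting end, as the values of compound 1 and compound 3 are limits: the limit of > 100000 nM in this assay, at which 2 of the 4 values shown sit.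

The compounds shown leave open whether a shorter or longer chain, an amine or a carboxylic acid in place of heptyl would give a lower or a higher number on either core. They also leave open how the same change would run on a core carrying fluoro or methoxy groups in place of the nitro or nitrile groups.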